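A few compounds are considered here, and "the series" means these few. Any claim that something is new, unique, unknown or untested is made for them only; others in the source may bear on it.

Compound 1 `CCn1c(CNc2ccccc2)nnc1SCC(=O)Nc1ccccc1` was tested in an assay on isolated protein for inhibition of long-chain fatty acid transport protein 1 (Mus musculus); a higher number here means a weaker inhibitor, a lower number a stronger inhibitor. In this assay compound 1 gives > 10000 nM, which is a limit of the assay and not a number. Compound 2 `CCn1c(CNc2ccccc2)nnc1SCc1nc2cc(C(=O)C(C)C)ccc2o1` gives 520 nM in this assay. Compound 3 `CC/C(=N/OC)c1ccc2oc(CSc3nnc(CNc4ccccc4)n3CC)nc2c1` gives > 10000 nM in this assay, again a limit rather than a number. Within the data shown here, the one step between two measured compounds that differ in a single place is an at least 19-fold higher number from compound 2 to compound 3 (1.28 log units; beyond the scatter): a change on an aromatic carbon at the far end of the molecule moved the value by a large amount. Compound 4 `CCOC(=O)c1ccc(NC(=O)CSc2nnc(CNc3ccccc3)n2CC)cc1` differs from compound 1 by ethoxycarbonyl in place of hydrogen on an aromatic carbon. The measured step shows that a change on an aromatic carbon of the distal ring can shift this assay strongly, but it does not show in which direction an added ethoxycarbonyl on the anilide ring will act, and the starting point for compound 1 is itself only a limit (the limit of > 10000 nM in this assay, at which 2 of the 3 values shown sit). Compound 4 is therefore expected to give about 8000 nM in this assay, within 1500 nM to 30000 nM, so that the expected step is an at least 1.2-fold lower number from compound 1 to compound 4 (0.09 log units; that floor lies within the scatter).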

Compound 4, half-maximal inhibitory concentration: 1100 nM
The estimate for compound 4 lay 7.3-fold (0.86 log units) above the measured number; measured number below the stated range.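

In this assay, the step is an at least 9.0-fold lower number from compound 1 to compound 4 (0.95 log units; beyond the scatter), so ethoxycarbonyl in place of hydrogen on this aromatic carbon, para to a large group, gives a stronger inhibitor. Among these compounds, the one earlier step showed only that a change on an aromatic carbon could weaken inhibition, whereas this one shows a gain on the ring of compound 1 and brings the value within measurable range. Compound 1 stands at a limit and not a number, so this step gives only a floor for the size of the gain: the limit of > 10000 nM in this assay, at which 2 of the 4 values shown sit.

The compounds shown leave open whether the gain needs ethoxycarbonyl as such or would also come with a carboxylic acid, a methyl ester or a primary amide on the same carbon. They also leave open whether ethoxycarbonyl would act alike on another carbon of that ring.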